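The source may hold more compounds than are shown below. What is called first, only, known or untested is meant among the compounds shown, and "the series" means these compounds.

Three compounds share one core and differ only in the aryl group on the urea. Compound 1 `CN(C)CCNc1nc(-c2ccc(NC(=O)Nc3ccccc3F)cc2)nc2ccsc12` carries a 2-fluorophenyl there; compound 2 `CN(C)CCNc1nc(-c2ccc(NC(=O)Nc3ccc(Cl)cc3)cc2)nc2ccsc12` a 4-chlorophenyl; compound 3 `CN(C)CCNc1nc(-c2ccc(NC(=O)Nc3ccccc3Cl)cc2)nc2ccsc12` a 2-chlorophenyl. In a functional assay on MKN-45 cells (Homo sapiens) for cytotoxicity, read by MTT assay, with a stated time of 72 h (a lower number here means a stronger inhibitor, a higher number a weaker inhibitor), compound 1 gives 530 nM, compound 2 gives 250 nM, and compound 3 gives 850 nM. Compound 1 thus stands second highest of the three numbers: its nearest neighbour is compound 3, with a 1.6-fold higher number from compound 1 to compound 3 (0.21 log units; within the scatter), and its furthest is compound 2, with a 2.1-fold lower number from compound 1 to compound 2 (0.33 log units; beyond the scatter). The remaining step, a 3.4-fold higher number from compound 2 to compound 3 (0.53 log units; beyond the scatter), likewise concerns only the urea aryl.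

Compound 4 `CCN(CC)CCCNc1nc(-c2ccc(NC(=O)Nc3ccccc3F)cc2)nc2ccsc12` leaves that aryl untouched and instead alters the amine chain: (diethylamino)methyl in place of dimethylamino on a saturated chain carbon, two bonds along the chain from a nitrogen on an aromatic ring, so that the (2-(dimethylamino)ethyl)amino of compound 1 becomes (3-(diethylamino)propyl)amino. Among the measured compounds shown here, none of the measured steps touches this part of the molecule, so there is no direct precedent for its effect in this assay. With nothing to point either way, the expected step is a 1.1-fold lower number from compound 1 to compound 4 (0.03 log units; within the scatter), a change not expected to exceed the scatter. Compound 4 is therefore estimated at 500 nM in this assay, within a range of 180 nM to 1400 nM.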

Compound 4, half-maximal inhibitory concentration: 580 nM
Estimate against measurement, compound 4: 1.2-fold (0.06 log units) below; the range from low to high includes it.
By their numbers in this assay, from the lowest: compound 2; then compounds 1, 4 and 3 (each within the scatter of the next).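

In this assay, the (3-(diethylamino)propyl)amino of compound 4 in place of the (2-(dimethylamino)ethyl)amino of compound 1 gives a 1.1-fold higher number from compound 1 to compound 4 (0.04 log units; within the scatter), so at this saturated chain carbon a (diethylamino)methyl, with 6 heavy atoms, takes the place of a dimethylamino, with 3, without a change in the number beyond the scatter. Among the compounds shown here, the earlier compounds varied only the urea aryl, where one step, a 3.4-fold higher number from compound 2 to compound 3 (0.53 log units; beyond the scatter), went beyond the scatter; this is the first reading on the amine chain, taken with the 2-fluorophenyl urea held fixed. Nothing measured alongside these numbers accounts for this result.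

Chain length and the alkyl groups on the terminal nitrogen differ together here, so the compounds shown do not separate them: a 3-(dimethylamino)propyl or a 2-(diethylamino)ethyl chain would be needed for that. Also open, from the compounds shown here alone, are chains ending in a cyclic amine such as morpholine or in a hydroxyl group, and whether the same chain change reads alike with the 4-chlorophenyl urea of compound 2.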